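The source may report more compounds than this note shows. Statements on the series, on what has been measured and on what is new or still open speak of the compounds shown alone.

In a functional assay on RKO cells (Homo sapiens) for cytotoxicity, read by resazurin assay, with a stated time of 72 h (a lower number here means a stronger inhibitor, a higher number a weaker inhibitor), three compounds have been read so far. Compound 1 `Cc1cn(-c2csc(Nc3ccc(Br)cc3)n2)c(C)n1` gives 400 nM. Compound 3 `Cc1nccn1-c1csc(Nc2ccc(Br)cc2)n1` gives 30000 nM, the higher of the two actual numbers, which makes it the weaker of that pair. Compound 2 `Brc1ccc(Nc2nc(-n3cnc4ccccc43)cs2)cc1` returns only a limit, > 100000 nM.

The next compound, compound 4 `Cc1nccn1-c1csc(Nc2ccccc2)n1`, differs from compound 3 at one place: hydrogen in place of bromo on an aromatic carbon. This puts hydrogen in place of bromo on an aromatic carbon of the six-membered aromatic ring of carbon only, para to a large group. Among the compounds with values here, no measured step touches this place, since all three measured compounds carry the bromo. Within the data shown here, the only measured step between two compounds is a 75-fold higher number from compound 1 to compound 3 (1.88 log units; beyond the scatter), which puts hydrogen in place of methyl on an aromatic carbon at a different place. It is large and beyond the scatter, so it shows that losing one small group can move the number far here. It gives only weak guidance on direction for the loss of the bromo, so a smaller rise is expected, with no change beyond the scatter also possible. The estimated step is a 1.7-fold higher number from compound 3 to compound 4 (0.22 log units; within the scatter). For compound 4 the expected value is 50000 nM, with an estimated range of 12000 nM to 100000 nM.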

Compound 4, half-maximal inhibitory concentration: 32500 nM
Estimate against measurement, compound 4: 1.5-fold (0.19 log units) above, and the stated range covers the measured number.
By their numbers in this assay, from the lowest: compound 1; then compounds 3 and 4 (each within the scatter of the next). At a limit, above all of these: compound 2.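

In this assay, within the data shown here, the first change on the six-membered aromatic ring of carbon only, para to a large group, barely registers: hydrogen in place of bromo gives a 1.1-fold higher number from compound 3 to compound 4 (0.03 log units; within the scatter). The bromo, carried by all three earlier compounds, is therefore not needed to hold the reading of compound 3, and this single-atom loss stands in sharp contrast to the other listed change, hydrogen in place of methyl on an aromatic carbon, which gave a 75-fold higher number from compound 1 to compound 3 (1.88 log units; beyond the scatter). Compound 2 remains a limit of the assay and not a number, so it offers no further step to set beside these two: the limit of > 100000 nM in this assay, at which 1 of the 4 values shown sits.

From the compounds shown here alone, this result comes only from the setting of compound 3, whose number is already far higher than that of compound 1, so whether the bromo counts in the setting of compound 1 remains open. The compounds shown also leave open how a methoxy group, an amine or a carboxylic acid would read in place of the bromo on this ring.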